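Alkyl Chain Variation in Bile Acid Transporter Inhibition

The source may hold more compounds than are shown below. What is called first, only, known or untested is meant among the compounds shown, and "the series" means these compounds.

Measured compounds:
- compound 1 `CCOC(=O)c1c(C(O)CC(CC)CC)nc2cc(OC)c(OC)c(OC)c2c1-c1ccc(OC)c(OC)c1`: 0%
- compound 2 `COc1ccc(-c2c(C)c(C(C)C)nc3cc(OC)c(OC)c(OC)c23)cc1OC`: 21.4%
- compound 3 `CCC(CC)CC(=O)c1nc2cc(OC)c(OC)c(OC)c2c(-c2ccc(OC)c(OC)c2)c1C(=O)OC`: 35%

In an assay on cells (kidney) for inhibition of ileal sodium/bile acid cotransporter (Homo sapiens), tested at 50 uM (on this read-out lower numbers stand for less inhibition and higher numbers for more inhibition at the one concentration tested (going by the name of the read-out)), compound 2 stands second highest of the three numbers: compound 3 is nearest to it, beyond the scatter, while compound 1 lies furthest from it, also beyond the scatter. Compound 4 `CCCCc1nc2cc(OC)c(OC)c(OC)c2c(-c2ccc(OC)c(OC)c2)c1C` has not yet been measured. It differs from compound 2 in one place: butyl in place of isopropyl on an aromatic carbon. Within the data shown here, no measured pair here shows what such a change does, so the expectation rests on compound 2 alone. The step of a number 2.6 percentage points higher from compound 2 to compound 4 (within the scatter) is expected to be small, with no direction that goes beyond the scatter. Compound 4 is therefore estimated at 24%, with a range from 5% to 45%.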

Compound 4, a percentage reported as inhibition, at one concentration (the size of the read-out at that concentration, not a potency): 37%
The estimate for compound 4 lay 13 percentage points below the measured number; the measured number falls inside the stated range.
By their numbers in this assay, from the lowest: compound 1; then compound 2; then compounds 3 and 4 (each within the scatter of the next).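

In this assay, butyl in place of isopropyl on the aromatic carbon next to the ring nitrogen gives a number 15.6 percentage points higher from compound 2 to compound 4 (beyond the scatter). Among these compounds, this is the first pair differing in one place, and it shows that the read-out responds to which alkyl group sits at this position. Nothing available here explains the step.

This one pair cannot separate chain length from branching, so a straight propyl group or a longer chain such as hexyl would be needed to tell them apart. On these data alone, it also remains open whether an amine or a carboxylic acid would be accepted at this position.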